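This account rests on a few compounds, and the source may have more. Where it says the series, first, only, none or still open, it means among the compounds named here.

Measured so far in a functional assay on CHO cells for agonist activity at Free fatty acid receptor 1 (Homo sapiens), read by FLIPR, tested at 100 nM; on this read-out higher numbers stand for a stronger effect at the one concentration tested and lower numbers for a weaker effect:

Compound 1, `COc1ccccc1NC(=O)C(=O)Nc1ccc(OCC(=O)O)c(F)c1`, gives 6.78%.
Compound 2, `Cc1ccccc1OCC(=O)Nc1ccc(OCC(=O)O)c(F)c1`, gives 20.8%.

Both compounds share the same core, an acid-bearing aryl amide, and differ in the group attached through the amide. Of the two numbers, compound 2 stands highest; its nearest neighbour is compound 1, whose number lies lower by a gap that goes beyond the usual scatter of this assay. Among the compounds with values here, no pair of measured compounds differs in only one place, so no single structural step has yet been tied to a change in the read-out.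

Compound 3, `COc1cccc(OCC(=O)Nc2ccc(OCC(=O)O)c(F)c2)c1`, has not been measured. It is built from compound 2 by one change: 3-methoxyphenyl in place of 2-methylphenyl on an oxygen on a saturated carbon. Within the data shown here, nothing among the measured compounds isolates this particular exchange, so the expectation rests on compound 2 alone. The step from compound 2 to compound 3 is expected to be small, most likely within the scatter, with a slight lean downward rather than upward. Compound 3 is therefore expected to give about 16% in this assay, with a likely range from 4% to 30%. That estimate means a step of a number 4.8 percentage points lower from compound 2 to compound 3 (within the scatter).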

Compound 3, a percentage reported as activity, at one concentration (the size of the read-out at that concentration, not a potency): 31.7%
Beside the measured number, compound 3's estimate is 15.7 percentage points below it, and the stated range ends below it.
By their numbers in this assay, from the lowest: compound 1; then compound 2; then compound 3.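

Within the data shown here, with the shared core held fixed, this is the first comparison that changes only one place: putting 3-methoxyphenyl in place of 2-methylphenyl on an oxygen on a saturated carbon gives, in this assay, a number 10.9 percentage points higher from compound 2 to compound 3 (beyond the scatter). The read-out is therefore sensitive to the aromatic group at this position, although the step is modest and comes from a single pair at one concentration, so it says nothing about potency. Nothing available explains the rise.

The exchange alters two things at once, the kind of substituent on the ring and its place there, and the compounds shown cannot separate them: 3-methylphenyl and 2-methoxyphenyl would be the direct tests, as each changes only one of the two. Also open, as far as these compounds go, is whether the gain depends on having a substituent at all, which plain phenyl would address, and whether it extends to other groups at this place on the ring, such as 3-chlorophenyl or a longer 3-ethoxyphenyl.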